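The source may report more compounds than this note shows. Statements on the series, on what has been measured and on what is new or still open speak of the compounds shown alone.

Values so far in an ADME assay on NHDF cells (Homo sapiens) for cytotoxicity, read by MTT assay, with a stated time of 72 h (a lower number here means a stronger inhibitor, a higher number a weaker inhibitor), for the series:

- compound 1 `COc1cccc(/C=C2\CCC/C(=C\c3cc(OC)c(OC)c(OC)c3)C2=O)c1OC` gives 7900 nM 
- compound 2 `COc1cccc(/C=C2\CCC/C(=C\c3ccc(OC)c(OC)c3)C2=O)c1` gives 11600 nM 
- compound 3 `COc1ccc(/C=C2\CCC/C(=C\c3ccc(OC)c(OC)c3)C2=O)cc1OC` gives 9700 nM 

Compound 3 lies within the scatter of both compound 2 and compound 1, so it has no clear rank among them. Compound 4 `COc1ccc(/C=C2\CCC/C(=C\c3cc(OC)c(OC)c(OC)c3)C2=O)cc1OC` carries methoxy in place of hydrogen on an aromatic carbon of compound 3: methoxy in place of hydrogen on an aromatic carbon. Among the compounds with values here, the only measured step of this kind is a 1.2-fold lower number from compound 2 to compound 3 (0.08 log units; within the scatter), and it stays within the scatter. No step beyond the scatter is therefore expected in this assay, and neither direction is favoured. The estimated change is a 1.1-fold lower number from compound 3 to compound 4 (0.03 log units; within the scatter), which is no real shift. For compound 4 the expected value is 9000 nM, with an estimated range of 5000 nM to 16000 nM.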

Compound 4, half-maximal inhibitory concentration: 5800 nM
Compound 4: middle estimate off by 1.6-fold (0.19 log units), on the high side, within the range that was stated.
By their numbers in this assay, from the lowest: compounds 4, 1, 3 and 2 (each within the scatter of the next).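

In this assay, methoxy in place of hydrogen on an aromatic carbon, here ortho to a methoxy group, stays within the scatter on the other aromatic ring too (a 1.7-fold lower number from compound 3 to compound 4 (0.22 log units; within the scatter)). Putting 3,4-dimethoxyphenyl in place of 2,3-dimethoxyphenyl on a double-bonded chain carbon bound to a double-bonded ring carbon also stays within the scatter (a 1.4-fold lower number from compound 1 to compound 4 (0.13 log units; within the scatter)), so neither change gives a clear shift. No evidence on the cause of these small steps is available.

Open, on these data alone, is whether an amine or a carboxylic acid in place of a methoxy group would move the number beyond the scatter.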